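Nitro in Place of Fluoro at a Second Ring Position

This account rests on a few compounds, and the source may have more. Where it says the series, first, only, none or still open, it means among the compounds named here.

Compound 1 `CC(=O)OC/C(=C\c1ccc(F)cc1)C(=O)c1ccccc1` is measured in a functional assay on SW1573 cells (Homo sapiens) for inhibition, read by sulforhodamine B assay, with a stated time of 48 h (on this read-out higher numbers stand for weaker inhibition of growth and lower numbers for stronger inhibition of growth), where compound 1 gives 4200 nM. Compound 2 `CC(=O)OC/C(=C\c1ccccc1F)C(=O)c1ccccc1` differs from it by 2-fluorophenyl in place of 4-fluorophenyl on a double-bonded chain carbon bound to a double-bonded chain carbon; in this assay compound 2 gives 6100 nM, a step of a 1.5-fold higher number from compound 1 to compound 2 (0.16 log units; within the scatter). Compound 3 `CC(=O)OC/C(=C\c1ccc([N+](=O)[O-])cc1)C(=O)c1ccccc1` carries nitro in place of fluoro on an aromatic carbon, and in this assay compound 3 gives 3800 nM, a step of a 1.1-fold lower number from compound 1 to compound 3 (0.04 log units; within the scatter).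

Compound 4 `CC(=O)OC/C(=C\c1ccccc1[N+](=O)[O-])C(=O)c1ccccc1` has not been measured. It differs from compound 2 by nitro in place of fluoro on an aromatic carbon. Among the measured compounds shown here, this is the same kind of change as the one from compound 1 to compound 3, but there the nitro stands para to a large group, here ortho to a large group. The step from compound 2 to compound 4 is expected to be a 1.1-fold lower number from compound 2 to compound 4 (0.04 log units; within the scatter), because the earlier step of a 1.1-fold lower number from compound 1 to compound 3 (0.04 log units; within the scatter) stayed within the scatter. Compound 4 is therefore estimated at 5500 nM, between 2500 nM and 12000 nM.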

Compound 4, concentration for 50% growth inhibition: 18000 nM
Compound 4: the middle estimate sits 3.3-fold (0.51 log units) below what was measured; the whole stated range lies below it.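

In this assay nitro in place of fluoro, ortho to a large group, gives a 3.0-fold higher number from compound 2 to compound 4 (0.47 log units; beyond the scatter) and so weaker inhibition of growth. The same change therefore does not carry over unchanged from one core to the other in this pair of cases: the same change on two cores in this assay, a 1.1-fold lower number (0.04 log units; within the scatter) from compound 1 to compound 3 and a 3.0-fold higher number (0.47 log units; beyond the scatter) from compound 2 to compound 4, 3.3-fold (0.51 log units) apart, beyond the scatter of two such steps

This shows that the outcome of the swap depends on the compound it is made on, but it does not show why, and two pairs cannot reveal how general this is.

The compounds shown leave open how other groups at these ring positions, such as an amine or a carboxylic acid, would compare with fluoro and nitro. They also leave open whether nitro and fluoro would differ in the same way on a core with a longer chain in place of the acetate.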